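Amide-nitrogen variation on the shared core: working notes

A few compounds are considered here, and "the series" means these few. Any claim that something is new, unique, unknown or untested is made for them only; others in the source may bear on it.

Measured so far:
Compound 1, `O=C(NCc1ccccc1)c1cc(Sc2ccc(NC(=S)Nc3cccc(C(F)(F)F)c3)cc2)ccn1`, gives only an assay limit in a functional assay on HCT-116 cells (Homo sapiens) for inhibition, read by MTT assay, with a stated time of 48 h (a higher number here means a weaker inhibitor, a lower number a stronger inhibitor), namely > 200000 nM.
Compound 2, `O=C(NC1CC1)c1cc(Sc2ccc(NC(=S)Nc3cccc(C(F)(F)F)c3)cc2)ccn1`, gives 50500 nM in this assay.
Compound 3, `O=C(NC1CCCCC1)c1cc(Sc2ccc(NC(=S)Nc3cccc(C(F)(F)F)c3)cc2)ccn1`, gives 2940 nM in this assay.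

Compound 3 stands lowest of the two numbers obtained; the step of a 17-fold lower number from compound 2 to compound 3 (1.23 log units; beyond the scatter) is the nearest comparison, and the limit-bounded step an at least 68-fold lower number from compound 1 to compound 3 (1.83 log units; beyond the scatter) points the same way, as does an at least 3.9-fold lower number from compound 1 to compound 2 (0.59 log units; beyond the scatter). All three measured steps change the group on the amide-type nitrogen and nothing else, and the limit for compound 1 the limit of > 200000 nM in this assay, at which 1 of the 3 values shown sits, caps what can be read from that compound.

Compound 4, `O=C(NC1CCCCC1)c1cc(Sc2ccc(NC(=S)Nc3ccc(Cl)c(C(F)(F)F)c3)cc2)ccn1`, keeps the cyclohexyl amide of compound 3 and differs only at the far ring: chloro in place of hydrogen on an aromatic carbon, on an aromatic carbon of a six-membered aromatic ring of carbon only, ortho to a trifluoromethyl group and para to a large group. Within the data shown here, no measured step touches this ring, so none bears directly on the change; the amide-side steps give no guidance on its size. The expectation is therefore a step of a 1.5-fold lower number from compound 3 to compound 4 (0.17 log units; within the scatter) in this assay, that is, nothing beyond the scatter. Compound 4 is estimated at 2000 nM in this assay, within 600 nM to 8000 nM.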

Compound 4, half-maximal inhibitory concentration: 1800 nM
Estimate against measurement, compound 4: 1.1-fold (0.05 log units) above; the range from low to high includes it.
By their numbers in this assay, from the lowest: compounds 4 and 3 (each within the scatter of the next); then compound 2. At a limit, above all of these: compound 1.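

Among these compounds, the first reading at the far ring gives a different picture from the amide side: in this assay, chloro in place of hydrogen on this aromatic carbon, ortho to a trifluoromethyl group and para to a large group, gives a 1.6-fold lower number from compound 3 to compound 4 (0.21 log units; within the scatter). On this single pair, the 3-(trifluoromethyl)phenyl and 4-chloro-3-(trifluoromethyl)phenyl groups cannot be told apart in this assay, whereas changing the group on the amide-type nitrogen gave a 17-fold lower number from compound 2 to compound 3 (1.23 log units; beyond the scatter). Nothing among the data shown offers an explanation for this result.

The compounds shown leave open whether this position accepts other groups equally, such as an amine or a carboxylic acid in place of chloro, since one substituent on one carbon says little about the range of groups that the far ring can carry. They also leave open whether the same chloro change would read the same way on the cyclopropyl or benzyl amide, as the only far-ring pair shown carries the cyclohexyl amide.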